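The source may report more compounds than this note shows. Statements on the series, on what has been measured and on what is new or still open speak of the compounds shown alone.

Measured compounds:
- compound 1 `Oc1cccc(-c2cc(-c3ccncc3)nc(-c3ccccc3Cl)c2)c1` — "not determined" (no result reported) in a functional assay on T47D cells (Homo sapiens) for cytotoxicity, read by CCK-8 assay and cell counting, with a stated time of 2 days; a higher number here means a weaker inhibitor, a lower number a stronger inhibitor
- compound 2 `Oc1ccc(-c2cc(-c3cccs3)nc(-c3ccccc3Cl)c2)cc1` — 5870 nM in this assay
- compound 3 `Oc1cccc(-c2cc(-c3ccccn3)nc(-c3ccccc3Cl)c2)c1` — "not determined" (no result reported) in this assay

Compound 3 stands without a number in this assay; compound 1 is likewise without one, so compound 2 alone supplies a measured value in this series. The step from compound 3 to compound 4 `Oc1cccc(-c2cc(-c3cccs3)nc(-c3ccccc3Cl)c2)c1` is thiophen-2-yl in place of pyridin-2-yl on an aromatic carbon. Among the compounds with values here, no measured pair shows a comparable step, and compound 3 itself gives no value from which a direction could be read, so the size of this step in this assay cannot be stated from the data. Compound 4 shares its thiophen-2-yl group and its 2-chlorophenyl group with compound 2 and differs from it only in the hydroxyphenyl group. On that ground compound 4 is expected to give a value in this assay near that of compound 2, estimated at 6000 nM, within a range from 2000 nM to 20000 nM.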

Compound 4, half-maximal inhibitory concentration: 3990 nM
Beside the measured number, compound 4's estimate is 1.5-fold (0.18 log units) above it; the range from low to high includes it.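

The step of a 1.5-fold lower number from compound 2 to compound 4 (0.17 log units; within the scatter) comes with 3-hydroxyphenyl in place of 4-hydroxyphenyl, while the thiophen-2-yl and 2-chlorophenyl groups stay the same. In this assay, these two placements of the hydroxyl group on the phenyl ring therefore cannot be told apart, and compound 4 at 3990 nM gives the only number shown for a 3-hydroxyphenyl compound. No measurement at hand offers an explanation for these values.

Going by these compounds, the step from compound 3 to compound 4 cannot be read, so how thiophen-2-yl compares with pyridin-2-yl on this aromatic carbon remains open. Also open, on these data alone, is whether an amine or a carboxylic acid at that place would move the number in this assay beyond the scatter.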